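Benzylic aryl swap in the bis(trifluoromethyl)sulfonamide series

The source may report more compounds than this note shows. Statements on the series, on what has been measured and on what is new or still open speak of the compounds shown alone.

Measured compounds:
compound 1 `CC(C)(C)c1ccc(CNCCCNS(=O)(=O)c2cc(C(F)(F)F)cc(C(F)(F)F)c2)cc1`, 2100 nM
compound 2 `O=S(=O)(NCCCNCc1ccc(Cl)c(Cl)c1)c1cc(C(F)(F)F)cc(C(F)(F)F)c1`, 2400 nM
compound 3 `O=S(=O)(NCCCNCc1ccc(C(F)(F)F)cc1)c1cc(C(F)(F)F)cc(C(F)(F)F)c1`, 1400 nM

All three were read in a functional assay on MCF7 cells (Homo sapiens) for inhibition, read by MTT assay, with a stated time of 72 h; a lower number here means a stronger inhibitor of growth, a higher number a weaker inhibitor of growth. Compound 3 gives the lowest number of the three, but its gap to compound 1 and to compound 2 is within the scatter, so no order among them can be claimed. Compound 4 `O=S(=O)(NCCCNCc1cccc2ccccc12)c1cc(C(F)(F)F)cc(C(F)(F)F)c1` is not yet measured. It differs from compound 3 by naphthalen-1-yl in place of 4-(trifluoromethyl)phenyl on a saturated chain carbon bound to an amine nitrogen.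

Two measured steps change the same place, the aryl group on the saturated chain carbon bound to the amine nitrogen: a 1.5-fold lower number from compound 1 to compound 3 (0.18 log units; within the scatter) and a 1.7-fold lower number from compound 2 to compound 3 (0.23 log units; within the scatter). Both are within the scatter, and the step of a 1.1-fold higher number from compound 1 to compound 2 (0.06 log units; within the scatter) between the other pair is too. Three different aryl groups at this position thus give numbers that cannot be told apart. The change to naphthalen-1-yl is of a similar kind, so no step beyond the scatter is expected in this assay, in either direction: a 1.3-fold higher number from compound 3 to compound 4 (0.11 log units; within the scatter) is the expected step. For compound 4 the estimate is 1800 nM, with a range of 700 nM to 4500 nM.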

Compound 4, concentration for 50% growth inhibition: 1400 nM
The estimate for compound 4 lay 1.3-fold (0.11 log units) above the measured number; low and high end bracket the measured number.
By their numbers in this assay, from the lowest: compounds 3, 4, 1 and 2 (each within the scatter of the next).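

In this assay, among these compounds, naphthalen-1-yl, the first group here with 2 six-membered aromatic rings of carbon only, cannot be told apart from the other three aryl groups (no change at the digits printed from compound 3 to compound 4 (within the scatter)) (a 1.7-fold lower number from compound 2 to compound 4 (0.23 log units; within the scatter)) (a 1.5-fold lower number from compound 1 to compound 4 (0.18 log units; within the scatter)). Across these four compounds, the number at this position on a saturated chain carbon bound to an amine nitrogen therefore tracks neither the count of aromatic rings nor the presence of trifluoromethyl on the aryl group. No supporting data bear on why these aryl groups read alike.

Still open, from the compounds shown here alone, is whether an aryl group carrying an amine or a carboxylic acid would move the number beyond the scatter in this assay. A longer chain in place of the present saturated chain is also untested in the compounds shown here, so its effect remains unknown.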